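Dihydrofuran amides: homologation of the anilide in compound 2

The compounds below may be only part of what the source reports. "The series", "measured", "known", "first", "only" and "open" are said of these compounds alone.

The series shares one core, a vinyl-substituted dihydrofuran carrying a carboxamide and an aryl group. Compound 1 `C=CC1=C(C(=O)NCCCCC)C(c2ccc(OC)cc2)OC1` bears a pentyl amide; in a functional assay on HeLa cells (Homo sapiens) for cytotoxicity, read by MTT assay, with a stated time of 24 h (on this read-out lower numbers stand for stronger inhibition and higher numbers for weaker inhibition), compound 1 reports only the limit > 100000 nM. Compound 3 `C=CC1=C(C(=O)NCCC)C(c2ccc(Cl)c(Cl)c2)OC1` carries a propyl amide and a dichlorophenyl group; in this assay compound 3 likewise stops at the limit > 100000 nM. Compound 2 `C=CC1=C(C(=O)Nc2ccc(C)cc2)C(c2ccc(F)cc2)OC1`, with a 4-methylphenyl amide and a fluorophenyl group, gives in this assay only the limit > 100000 nM. Compound 2 thus stands where every measured member of the series stands: the limit of > 100000 nM in this assay, at which 3 of the 3 values shown sit. Among the measured compounds shown here, no numerical value and no step between measured compounds is available.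

Compound 4 `C=CC1=C(C(=O)NCc2ccc(C)cc2)C(c2ccc(F)cc2)OC1` differs from compound 2 in one place: 4-methylbenzyl in place of 4-methylphenyl on an amide-type nitrogen.

With all three measured values sitting at the limit, no direction of change can be read from the series, and no step beyond the scatter is expected in this assay. Compound 4 is expected to report a limit again rather than a number; the estimate is 100000 nM with a range of 50000 nM to 200000 nM, and the step from compound 2 to compound 4 is expected to be a number no higher from compound 2 to compound 4 (the limit leaves the size open).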

Compound 4, half-maximal inhibitory concentration: > 100000 nM
Compound 4: a limit, no number; the forecaster's own chance of this, stated with the estimate: 85%; the middle value sits exactly at the limit.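

In this assay, among the compounds shown here, compound 4 gives > 100000 nM, a limit and not a number; compound 2 also stands at a limit, so no step between compound 2 and compound 4 can be read. The compounds shown leave open how 4-methylbenzyl and 4-methylphenyl on the amide-type nitrogen compare, and whether any member of this series reaches a numerical value.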